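Replacing a Sulfur-Bearing Ring with 4-Phenylpiperazin-1-yl

The source may hold more compounds than are shown below. What is called first, only, known or untested is meant among the compounds shown, and "the series" means these compounds.

Compound 3 `Cn1c(-c2ccc(NC(=O)CSC3=NCCS3)cc2)nc(-c2ccccc2)c1-c1ccccc1` stands second highest of three numbers in a functional assay on HT-29 cells (Homo sapiens) for cytotoxicity, read by MTT assay, with a stated time of 24 h, tested at 16 ug/mL (on this read-out higher numbers stand for a stronger effect at the one concentration tested and lower numbers for a weaker effect), giving 43.3%. Compound 1 `Cc1ccc2oc(SCC(=O)Nc3ccc(-c4nc(-c5ccccc5)c(-c5ccccc5)n4C)cc3)nc2c1` gives 37.7% in this assay, and the gap is a number 5.6 percentage points higher from compound 1 to compound 3 (within the scatter). Compound 2 `Cn1cnnc1SCC(=O)Nc1ccc(-c2nc(-c3ccccc3)c(-c3ccccc3)n2C)cc1` gives 59.1%, so that a number 15.8 percentage points lower from compound 2 to compound 3 (beyond the scatter). Compound 4 `Cn1c(-c2ccc(NC(=O)CN3CCN(c4ccccc4)CC3)cc2)nc(-c2ccccc2)c1-c1ccccc1` differs from compound 3 by a group of 12 heavy atoms (10 carbon, 2 nitrogen; one six-membered non-aromatic ring with 2 hetero atoms, one six-membered aromatic ring of carbon only) in place of a group of 6 heavy atoms (3 carbon, 1 nitrogen, 2 sulfur; one five-membered non-aromatic ring with 2 hetero atoms), on a saturated chain carbon bound to a carbonyl carbon. For the measured compounds named here, no measured step touches this position: the three known steps, a number 21.4 percentage points higher from compound 1 to compound 2 (beyond the scatter), a number 5.6 percentage points higher from compound 1 to compound 3 (within the scatter) and a number 15.8 percentage points lower from compound 2 to compound 3 (beyond the scatter), all alter only the group on sulfur, and each stays modest. A shift of similar scale, in either direction, is therefore expected here, and the estimated step is a number 1.7 percentage points higher from compound 3 to compound 4 (within the scatter). Compound 4 is expected to give 45%, within a range of 25% to 65%.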

Compound 4, a percentage reported as activity, at one concentration (the size of the read-out at that concentration, not a potency): 55.4%
Compound 4: the middle estimate sits 10.4 percentage points below what was measured, within the range that was stated.
By their numbers in this assay, from the lowest: compounds 1 and 3 (each within the scatter of the next); then compounds 4 and 2 (each within the scatter of the next).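

In this assay, the group on the saturated chain carbon bound to a carbonyl carbon need not be attached through sulfur: 4-phenylpiperazin-1-yl gives a number 12.1 percentage points higher from compound 3 to compound 4 (beyond the scatter) and a number 17.7 percentage points higher from compound 1 to compound 4 (beyond the scatter), while the comparison with the triazole compound gives a number 3.7 percentage points lower from compound 2 to compound 4 (within the scatter). A group without that sulfur can therefore match (4-methyl-4H-1,2,4-triazol-3-yl)sulfanyl at this position. No supporting measurement explains this result. On these data alone, whether the phenyl ring on the piperazine matters remains open, as does how a 4-methylpiperazin-1-yl or morpholin-4-yl group would read in the same place.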